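This account rests on a few compounds, and the source may have more. Where it says the series, first, only, none or still open, it means among the compounds named here.

Compound 1: `O=C(Nc1cccnc1)c1ccccc1OCc1ccccc1`, 3200 nM
Compound 2: `O=C(Nc1cccnc1)c1ccccc1OCc1ccccc1OCCCCCl`, 1300 nM
Compound 3: `O=C(Nc1cccnc1)c1ccccc1OCc1ccccc1OCCCCCCCl`, not yet measured

In an assay on lysate for inhibition of phosphatidylcholine:ceramide cholinephosphotransferase 2 (Homo sapiens), read by HPLC, with stated times of 30 min and 2 h (a lower number here means a stronger inhibitor, a higher number a weaker inhibitor), compound 1 gives 3200 nM and compound 2 gives 1300 nM, so compound 2 stands with the lower of the two numbers. Within the data shown here, the single measured step, a 2.5-fold lower number from compound 1 to compound 2 (0.39 log units; beyond the scatter), came with a 4-chlorobutoxy group entering. Compound 3 differs from compound 2 by 2-chloroethyl in place of chloro on a saturated chain carbon, four bonds along the chain from an oxygen on an aromatic ring. Among the measured compounds shown here, no measured step lengthens that chain, so the one step is only an indirect guide, and a change within the scatter is expected, a 1.3-fold lower number from compound 2 to compound 3 (0.11 log units; within the scatter). Compound 3 is therefore estimated at 1000 nM, between 400 nM and 3000 nM.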

Compound 3, half-maximal inhibitory concentration: 470 nM
Estimate against measurement, compound 3: 2.1-fold (0.33 log units) above; low and high end bracket the measured number.
By their numbers in this assay, from the lowest: compound 3; then compound 2; then compound 1.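

In this assay the chain carbons added to the 4-chlorobutoxy group bring a further gain, with a 2.8-fold lower number from compound 2 to compound 3 (0.44 log units; beyond the scatter) for 2-chloroethyl in place of chloro. This position therefore had not yet stopped responding at compound 2. Measured from the unsubstituted parent, the (6-chlorohexyl)oxy group gives a 6.8-fold lower number from compound 1 to compound 3 (0.83 log units; beyond the scatter) and the number falls at each step of this short series, though no evidence on hand accounts for the change.

From the compounds shown here alone, whether a longer chain such as 8-chlorooctyl extends the gain remains open. So does what an amine in place of chloro would give.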